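A few compounds are considered here, and "the series" means these few. Any claim that something is new, unique, unknown or untested is made for them only; others in the source may bear on it.

Working notes on the series. Among the compounds with values here, compound 1 `CCOC(=O)/C=C/C(=O)N(CC(N)=O)NC(=O)[C@@H]1CCCN1C(=O)[C@H]1CSCN1C(C)=O` gives in an assay on isolated protein for inhibition of legumain (Mus musculus), read by fluorescence, with stated times of 30 s and 2.5 h (on this read-out higher numbers stand for weaker inhibition and lower numbers for stronger inhibition), a value of 167 nM; it is the only compound in the set with a number rather than a limit. Compound 2 `CCOC(=O)/C=C/C(=O)N(CC(N)=O)NC(=O)[C@@H]1CCCN1C(=O)[C@@H]1Cc2ccccc2CN1C(C)=O` reports in this assay only a limit, > 1000 nM, namely (the limit of > 1000 nM in this assay, at which 1 of the 2 values shown sits). Within the data shown here, no step between two measured compounds can be drawn, and the size of any change therefore has no calibration within the set. Compound 3 `CCOC(=O)/C=C/C(=O)N(CC(N)=O)NC(=O)[C@@H]1CCCN1C(=O)C1(NC(C)=O)CC1` is not yet measured. It differs from compound 1 by a group of 7 heavy atoms (5 carbon, 1 nitrogen, 1 oxygen; one three-membered non-aromatic ring of carbon only) in place of a group of 8 heavy atoms (5 carbon, 1 nitrogen, 1 oxygen, 1 sulfur; one five-membered non-aromatic ring with 2 hetero atoms), on a carbonyl carbon. Among the measured compounds shown here, the acetylated five-membered ring with two hetero atoms is the only piece that separates compound 1 from compound 3, and nothing measured here tells how much weight it carries. The expected step is a 2.4-fold higher number from compound 1 to compound 3 (0.38 log units; beyond the scatter), toward weaker inhibition and beyond the scatter. Compound 3 is estimated in this assay at 400 nM, within a range of 120 nM to 1500 nM.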

Compound 3, half-maximal inhibitory concentration: 9.3 nM
The estimate for compound 3 lay 43-fold (1.63 log units) above the measured number, outside the stated range (below it).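

Replacing the acetylated five-membered ring with 1-acetamidocyclopropyl on this carbonyl carbon gives, in this assay, an 18-fold lower number from compound 1 to compound 3 (1.25 log units; beyond the scatter), toward stronger inhibition, so this position can move the read-out by a large step. The swap also brings a hydrogen-bond donor that the leaving group lacks and removes the sulfur along with the five-membered ring, and a single step cannot separate these changes from one another. Nothing measured here accounts for the size of the step.

On these data alone, it remains open whether the step follows the three-membered ring itself or the amide hydrogen, which a cyclobutyl ring or a gem-dimethyl carbon carrying the same acetamide could help to separate. As far as these compounds go, it is also open whether the same step would hold on a core with the ethyl ester replaced by a carboxylic acid.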